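Series notes: 3-carboxyphenyl replacing 4-fluorophenyl on compound 2

The compounds below may be only part of what the source reports. "The series", "measured", "known", "first", "only" and "open" are said of these compounds alone.

Compound 1 `COc1ccccc1C1CCCN1C(=O)C(Nc1ccccc1)c1ccc(C(F)(F)F)cc1`: 33 nM
Compound 2 `O=C(C(Nc1ccccc1F)c1ccc(C(F)(F)F)cc1)N1CCCC1c1ccc(F)cc1`: 37 nM
Compound 3 `O=C(C(Nc1ccc(F)cc1)c1ccc(C(F)(F)F)cc1)N1CCCC1c1ccccc1Cl`: 73 nM

All three were measured in an assay on HEK293 cells for antagonist activity at transient receptor potential M8 protein (Canis lupus familiaris), read by fluorescence and calcium flux, with a stated time of 5 min; a lower number here means a stronger inhibitor, a higher number a weaker inhibitor. Among them compound 2 gives the second highest number; its gaps to compound 1 and to compound 3 both lie within the scatter, so no order among the three is claimed.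

Compound 4 `O=C(O)c1cccc(C2CCCN2C(=O)C(Nc2ccccc2F)c2ccc(C(F)(F)F)cc2)c1` differs from compound 2 by 3-carboxyphenyl in place of 4-fluorophenyl on a saturated ring carbon. For the measured compounds named here, no pair of measured compounds shows a step of this kind, so the size cannot be read from the measured values. The expectation is a weakening beyond the scatter, a step estimated at an 8.1-fold higher number from compound 2 to compound 4 (0.91 log units; beyond the scatter). Compound 4 is accordingly expected to give about 300 nM in this assay, with a range from 60 nM to 1500 nM.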

Compound 4, half-maximal inhibitory concentration: 40 nM
Beside the measured number, compound 4's estimate is 7.5-fold (0.88 log units) above it; the measured number lies below the stated range.
By their numbers in this assay, from the lowest: compounds 1, 2, 4 and 3 (each within the scatter of the next, the first and the last beyond it).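

In this assay, 3-carboxyphenyl in place of 4-fluorophenyl on the saturated ring carbon gives a 1.1-fold higher number from compound 2 to compound 4 (0.03 log units; within the scatter) and so leaves the number unmoved. The earlier compounds shown here varied this group without a hydrogen-bond donor, whereas compound 4 shows that one can be carried here, on a group with more heavy atoms, at no measurable cost in this assay.

On these data alone, whether a methyl ester or an amine in place of the carboxylic acid would behave the same stays open. The reason for this result also stays open, with no supporting evidence at hand.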